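A few compounds are considered here, and "the series" means these few. Any claim that something is new, unique, unknown or untested is made for them only; others in the source may bear on it.

In a functional assay on the whole organism (strain Sprague-Dawley) for inhibition, with Rattus norvegicus as the target, with a stated time of 10 min (on this read-out lower numbers stand for an effect already at smaller amounts and higher numbers for an effect only at larger amounts of compound), compound 3 `CCOC(=O)c1cnc(-c2ccccc2Cl)[nH]c1=O` gives 5 mg/kg. Within the data shown here, compound 1 `O=C(O)c1cnc(-c2ccccc2Cl)[nH]c1=O` gives 5 mg/kg, level with it, and together they hold the highest number of the three measured so far, while compound 2 `O=C(O)c1cnc(-c2ccccc2OCC2CC2)[nH]c1=O` gives 0.1 mg/kg. The unmeasured compound 4 `CCOC(=O)c1cnc(-c2ccccc2OC)[nH]c1=O` keeps the ethyl group of compound 3 but carries methoxy in place of chloro on an aromatic carbon.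

Among the measured compounds shown here, two measured steps bear on this change. Adding the ethyl group gave no change at the digits printed from compound 1 to compound 3 (within the scatter), so in this one pair the ethyl group left the number as it was. For the measured compounds named here, the closest precedent for replacing chloro is a 50-fold lower number from compound 1 to compound 2 (1.70 log units; beyond the scatter), a large step made with cyclopropylmethoxy and without the ethyl group. Going by the values given here, no compound with methoxy has been measured, so only part of that large step is expected to carry over, in the same direction. The step expected in this assay is a 5.0-fold lower number from compound 3 to compound 4 (0.70 log units; beyond the scatter). Compound 4 is estimated at 1 mg/kg, with an expected range of 0.2 mg/kg to 5 mg/kg.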

Compound 4, dose for 50% inhibition: 10 mg/kg
Estimate against measurement, compound 4: 10-fold (1.00 log units) below; measured number above the stated range.
By their numbers in this assay, from the lowest: compound 2; then compounds 1, 3 and 4 (each within the scatter of the next).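

In this assay methoxy in place of chloro on this aromatic carbon gives a 2.0-fold higher number from compound 3 to compound 4 (0.30 log units; within the scatter), so with the ethyl group in place the two groups are not told apart. Among these compounds, an oxygen-linked group at this position therefore does not by itself bring the number down: the large step of a 50-fold lower number from compound 1 to compound 2 (1.70 log units; beyond the scatter) has no counterpart in this pair, and it stands only for cyclopropylmethoxy without the ethyl group. Nothing available gives a reason for this result.

As far as these compounds go, those two steps differ both in the entering group and in the ethyl group, so it stays open whether the low number of compound 2 0.1 mg/kg rests on cyclopropylmethoxy alone or also needs the free acid. From the compounds shown here alone, how a longer chain such as butoxy, or an amine, would read on this aromatic carbon also stays open.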